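Benzyl-substituted nucleosides and their cytotoxicity on fibroblasts

The source may hold more compounds than are shown below. What is called first, only, known or untested is meant among the compounds shown, and "the series" means these compounds.

Measured so far:
Compound 1 `OC[C@H]1O[C@@H](n2cnc3c(NCc4ccccc4F)ncnc32)[C@H](O)[C@@H]1O` gives > 166000 nM
Compound 2 `OC[C@H]1O[C@@H](n2cnc3c(NCc4ccc(Cl)cc4Cl)ncnc32)[C@H](O)[C@@H]1O` gives "not determined" (no result reported)

In an ADME assay on NIH3T3 cells (Mus musculus) for cytotoxicity, with a stated time of 72 h (a lower number here means a stronger inhibitor, a higher number a weaker inhibitor), compound 1 reaches only the limit of the assay, > 166000 nM, and is reported as a limit rather than a number. For compound 2 this assay gives "not determined" (no result reported), so no number stands for it. For the measured compounds named here, the one value shown is a limit, (the limit of > 166000 nM in this assay, at which 1 of the 2 values shown sits).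

Compound 3 `COc1cccc(CNc2ncnc3c2ncn3[C@@H]2O[C@H](CO)[C@@H](O)[C@H]2O)c1O` differs from compound 2 by 2-hydroxy-3-methoxyphenyl in place of 2,4-dichlorophenyl on a saturated chain carbon bound to a nitrogen on an aromatic ring. Going by the values given here, no measured step between these compounds exists, so no size or direction of change beyond the scatter can be stated. Compound 3 is expected to give about 150000 nM in this assay, within a range from 50000 nM to 400000 nM.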

Compound 3, half-maximal inhibitory concentration: > 166000 nM
Compound 3 ended at the assay's limit; the forecaster's own chance of this, stated with the estimate: 70%; middle value at least 1.1-fold (0.04 log units) away from the limit.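

No step can be read between compound 1 and compound 3 in this assay, since both values are limits: the limit of > 166000 nM in this assay, at which 2 of the 3 values shown sit.

The compounds shown leave open whether the 2-fluorophenyl and 2-hydroxy-3-methoxyphenyl groups differ in this read-out, and where compound 2 stands.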